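The compounds below may be only part of what the source reports. "The series", "measured", "known", "first", "only" and "open" are said of these compounds alone.

Measured so far in a functional assay on A549 cells (Homo sapiens) for antiproliferative activity, read by MTT assay, with a stated time of 72 h; a higher number here means a weaker inhibitor, a lower number a stronger inhibitor:
- Compound 1 `CC(=O)N(C)c1ccc2[nH]c(-c3n[nH]c4ccccc34)cc2n1`: > 50000 nM.
- Compound 2 `CCC(=O)N(C)c1ccc2[nH]c(-c3n[nH]c4ccccc34)cc2n1`: 15700 nM.
- Compound 3 `CN(C(=O)c1ccc(F)cc1)c1ccc2[nH]c(-c3n[nH]c4ccccc34)cc2n1`: 9650 nM.

Compound 1 stands at the limit of > 50000 nM in this assay, at which 1 of the 3 values shown sits, so its entry is a limit of the assay and not a number.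

Compound 4 `COc1ccc(C(=O)N(C)c2ccc3[nH]c(-c4n[nH]c5ccccc45)cc3n2)cc1` has not been measured yet. It differs from compound 1 as follows: 4-methoxyphenyl in place of methyl on a carbonyl carbon. In words, this is 4-methoxyphenyl in place of methyl on a carbonyl carbon.

The closest measured change is an at least 5.1-fold lower number from compound 1 to compound 3 (0.71 log units; beyond the scatter), with 4-fluorophenyl in place of methyl on the same carbonyl carbon. A smaller change at that spot, methyl in place of hydrogen on the chain, gives an at least 3.1-fold lower number from compound 1 to compound 2 (0.50 log units; beyond the scatter). Both steps point towards a lower number, and both are only minimum sizes. Going from ethyl to 4-fluorophenyl gives a 1.6-fold lower number from compound 2 to compound 3 (0.21 log units; within the scatter).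

A step of similar size and direction is therefore expected, with compound 4 landing near compound 3 at 9650 nM. The expected step is an at least 4.5-fold lower number from compound 1 to compound 4 (0.65 log units; beyond the scatter). The estimate for compound 4 is 11000 nM, within an expected range of 4000 nM to 30000 nM.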

Compound 4, half-maximal inhibitory concentration: 14600 nM
For compound 4 the middle estimate is 1.3-fold (0.12 log units) below the measured one; measured number inside the range.
By their numbers in this assay, from the lowest: compounds 3, 4 and 2 (each within the scatter of the next). At a limit, above all of these: compound 1.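

In this assay, a second aromatic group on the carbonyl carbon also gives a lower number, an at least 3.4-fold lower number from compound 1 to compound 4 (0.53 log units; beyond the scatter), so the drop seen with 4-fluorophenyl is not confined to that one group. Compound 1 is a limit of the assay and not a number, so this step gives only a minimum size: the limit of > 50000 nM in this assay, at which 1 of the 4 values shown sits.

Putting methoxy in place of fluoro on the aromatic carbon gives no readable difference, a 1.5-fold higher number from compound 3 to compound 4 (0.18 log units; within the scatter), and neither does putting 4-methoxyphenyl in place of ethyl, a 1.1-fold lower number from compound 2 to compound 4 (0.03 log units; within the scatter), so ethyl, 4-fluorophenyl and 4-methoxyphenyl cannot be told apart at this place.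

The compounds shown leave open whether a group carrying an amine or a carboxylic acid, or a longer chain such as butyl, on the carbonyl carbon would move the number beyond the scatter. They also leave open whether plain phenyl there would differ from the two substituted rings.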